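A second chloro on compound 2: expected effect on growth

The source may report more compounds than this note shows. Statements on the series, on what has been measured and on what is new or still open speak of the compounds shown alone.

Compound 2 `COc1ccc(Cn2cnc3c(Cl)ncnc32)cc1OC` reads > 100000 nM in a functional assay on AGS cells (Homo sapiens) for antiproliferative activity, read by MTT assay, with a stated time of 48 h (a lower number here means a stronger inhibitor of growth, a higher number a weaker inhibitor of growth), and this is a limit of the assay, not a number. Going by the values given here, compound 1 `COc1ccc(N(C)c2nc(Cl)nc3c2ncn3Cc2ccc(OC)c(OC)c2)cc1` gives 56000 nM in this assay and so holds the only true number so far. Compound 3 `COc1ccc(Cn2cnc3c(Cl)nc(Cl)nc32)cc1OC` follows from compound 2 by the change chloro in place of hydrogen on an aromatic carbon with chloro in place of hydrogen on an aromatic carbon, between two ring nitrogen atoms. Among the compounds with values here, no measured step isolates this change. Compound 1 carries chloro on that same carbon and gives 56000 nM in the measurable range, so a modest gain in growth inhibition is expected in this assay for the new compound. A reading at the limit of the assay remains possible for compound 3. The expected change is an at least 1.6-fold lower number from compound 2 to compound 3 (0.22 log units; that floor lies within the scatter) as a rough estimate. For compound 3 the estimated value is 60000 nM with an expected range from 20000 nM to 100000 nM on present data.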

Compound 3, concentration for 50% growth inhibition: 11000 nM
For compound 3 the middle estimate is 5.5-fold (0.74 log units) above the measured one; the whole stated range lies above it.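

On the aromatic carbon between two ring nitrogen atoms, chloro in place of hydrogen gives, in this assay, an at least 9.0-fold lower number from compound 2 to compound 3 (0.95 log units; beyond the scatter), so this position responds to the change. That size is only a floor, because compound 2 stands at a limit and not at a number: the limit of > 100000 nM in this assay, at which 1 of the 3 values shown sits.

Chloro in place of (4-methoxyphenyl)(methyl)amino on an aromatic carbon gives a 5.1-fold lower number from compound 1 to compound 3 (0.71 log units; beyond the scatter), so the (4-methoxyphenyl)(methyl)amino group of compound 1 is not required for growth inhibition in this series.

The position between two ring nitrogen atoms is shown only with hydrogen and chloro, so it remains open whether the gain is specific to chloro or would also appear with fluoro or a primary amine. Also open, from the compounds shown here alone, is how far the other chloro of compound 3 can be exchanged, for example for a primary amine, without losing growth inhibition.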